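Ethylsulfanyl in Place of Isopropoxy: Expected Potency

The compounds below may be only part of what the source reports. "The series", "measured", "known", "first", "only" and "open" are said of these compounds alone.

Compounds measured in a functional assay on the whole organism (strain Sprague-Dawley) for inhibition, with Rattus norvegicus as the target, with a stated time of 10 min; a higher number here means that more compound is needed for the effect, a lower number that less compound is needed:
- Compound 1, `O=C(O)c1cnc(-c2ccccc2O)[nH]c1=O`, gives only a limit of the assay, > 5 mg/kg.
- Compound 2, `CCCOc1ccccc1-c1ncc(C(=O)O)c(=O)[nH]1`, gives 0.9 mg/kg.
- Compound 3, `CC(C)Oc1ccccc1-c1ncc(C(=O)O)c(=O)[nH]1`, gives 0.8 mg/kg.

Compound 3 has the lowest of the two numbers shown, and compound 2 sits within the scatter of it. Compound 4, `CCSc1ccccc1-c1ncc(C(=O)O)c(=O)[nH]1`, has not yet been measured. It differs from compound 3 in one place: ethylsulfanyl in place of isopropoxy on an aromatic carbon. Among the measured compounds shown here, three measured steps bear on this change. Putting propyl or isopropyl on the oxygen gave an at least 5.5-fold lower number from compound 1 to compound 2 (0.74 log units; beyond the scatter) and an at least 6.2-fold lower number from compound 1 to compound 3 (0.79 log units; beyond the scatter). Both of these steps start from compound 1, whose value is only a limit, (the limit of > 5 mg/kg in this assay, at which 1 of the 3 values shown sits). Between the two alkyl groups themselves there was a 1.1-fold lower number from compound 2 to compound 3 (0.05 log units; within the scatter). These steps show that an alkyl group at this position lowers the number, while the choice between propyl and isopropyl does not shift it beyond the scatter. Compound 4 keeps an alkyl group at the same place, on sulfur rather than oxygen. For the measured compounds named here, no measured step covers the exchange of oxygen for sulfur. The expectation for compound 4 in this assay is therefore a step of a 1.3-fold higher number from compound 3 to compound 4 (0.10 log units; within the scatter), within the scatter. Compound 4 is estimated at 1 mg/kg, with a range from 0.4 mg/kg to 2.5 mg/kg.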

Compound 4, dose for 50% inhibition: 25 mg/kg
The estimate for compound 4 lay 25-fold (1.40 log units) below the measured number, and the stated range ends below it.
By their numbers in this assay, from the lowest: compounds 3 and 2 (each within the scatter of the next); then compound 4.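

In this assay, among the compounds shown here, the place on the aromatic carbon proves far less forgiving than the earlier compounds suggested: ethylsulfanyl gave a 31-fold higher number from compound 3 to compound 4 (1.49 log units; beyond the scatter), and against the propoxy group it gave a 28-fold higher number from compound 2 to compound 4 (1.44 log units; beyond the scatter). Until now, only the choice between propoxy and isopropoxy had been compared among alkyl groups, and that choice stayed within the scatter, whereas these large steps show that a group carrying an alkyl chain here does not by itself secure a low number. The step from compound 1 to compound 4 cannot be read, as compound 1 gives only a limit of the assay: the limit of > 5 mg/kg in this assay, at which 1 of the 4 values shown sits.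

The change from compound 3 to compound 4 exchanges oxygen for sulfur and alters the alkyl group at the same time, so the compounds shown do not tell which of the two carries the step. An ethoxy group or an isopropylsulfanyl group at this place would separate the two, and the compounds shown also leave open how a longer chain on sulfur would read.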